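From butyl to isopropyl at the clearance limit

This account rests on a few compounds, and the source may have more. Where it says the series, first, only, none or still open, it means among the compounds named here.

Measured so far in an ADME assay on microsomes from liver (Homo sapiens) for metabolic stability, read by LC-MS, using NADPH (a higher number here means faster removal of the compound, a lower number slower removal), are these compounds:
Compound 1 `CCOC(=O)c1cc(C#N)c(N2CCN(C(=O)NS(=O)(=O)c3ccc(Cl)cc3)CC2)nc1C(F)(F)F` gives > 70000 mL.min-1.g-1 as a limit.
Compound 2 `CCOC(=O)c1cnc(N2CCN(C(=O)NS(=O)(=O)c3ccc(Cl)s3)CC2)c(Cl)c1` gives > 70000 mL.min-1.g-1 as a limit.
Compound 3 `CCCCOC(=O)c1cnc(N2CCN(C(=O)NS(=O)(=O)c3ccc(Cl)s3)CC2)c(Cl)c1` gives > 70000 mL.min-1.g-1 as a limit.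

Compound 3 therefore has no number, only a limit of the assay. Taken together, the data show the limit of > 70000 mL.min-1.g-1 in this assay, at which 3 of the 3 values shown sit, and nothing finer.

Compound 4 `CC(C)OC(=O)c1cnc(N2CCN(C(=O)NS(=O)(=O)c3ccc(Cl)s3)CC2)c(Cl)c1` differs from compound 3 by isopropyl in place of butyl on an oxygen next to a carbonyl group in one place, with isopropyl in place of butyl on an oxygen next to a carbonyl group. Within the data shown here, one measured step bears on the chain at that oxygen. It is a step that the two limits leave unreadable from compound 2 to compound 3 and arises from ethyl in place of hydrogen on a saturated chain carbon, two bonds along the chain from an oxygen next to a carbonyl group. That step offers neither a size nor a direction to carry over.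

No shift can therefore be predicted with any confidence, and compound 4 is expected to stay at or close to the same limit. The expected step is a number no higher from compound 3 to compound 4 (the limit leaves the size open) and the data support no direction for it. In this assay the estimate for compound 4 is 70000 mL.min-1.g-1 with an expected range from 20000 mL.min-1.g-1 to 120000 mL.min-1.g-1 and a report of the limit as the likeliest outcome.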

Compound 4, intrinsic clearance in microsomes in the Homo sapiens assay: > 70000 mL.min-1.g-1
Compound 4: only a limit was reported; the forecaster's own chance of this, stated with the estimate: 70%; the middle value lies on the limit itself.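

In the Homo sapiens assay compound 4 gives > 70000 mL.min-1.g-1, which is a limit of the assay and not a number. Among these compounds, no new step to compound 4 can be read. The compounds shown leave open how fast each is removed and whether the chain on the oxygen next to a carbonyl group matters at all, with every value at one limit: the limit of > 70000 mL.min-1.g-1 in the Homo sapiens assay, at which 4 of the 4 values shown sit.

In a physicochemical assay (a higher number here means that more of the compound is left, a lower number that less of the compound is left), compound 3 gives "stable" (no number reported). In the physicochemical assay compound 4 gives "stable" (no number reported). Neither result comes with a number.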